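Swapping a tert-Butyl for Methoxycarbonyl on a Shared Core

The source may report more compounds than this note shows. Statements on the series, on what has been measured and on what is new or still open speak of the compounds shown alone.

Compound 1 `NS(=O)(=O)NCCC1CCN(c2cc(-c3ccccc3)ncn2)CC1`: 53200 nM
Compound 2 `CC(C)(C)c1ccc(-c2cc(N3CCC(CCNS(N)(=O)=O)CC3)ncn2)cc1`: 13100 nM

In a functional assay on MCF7 cells (Homo sapiens) for antiproliferative activity, read by sulforhodamine B assay, with a stated time of 48 h (on this read-out higher numbers stand for weaker inhibition of growth and lower numbers for stronger inhibition of growth), compound 2 holds the lower of the two numbers, and the step of a 4.1-fold lower number from compound 1 to compound 2 (0.61 log units; beyond the scatter) lies beyond the usual scatter. Compound 3 `COC(=O)c1ccc(-c2cc(N3CCC(CCNS(N)(=O)=O)CC3)ncn2)cc1` differs from compound 2 by methoxycarbonyl in place of tert-butyl on an aromatic carbon. Going by the values given here, only that one measured step bears on this change, and it concerns a different group at the same place, so it offers limited guidance. The change is expected to bring a modest shift toward weaker growth inhibition for compound 3, a 1.9-fold higher number from compound 2 to compound 3 (0.28 log units; within the scatter). For compound 3 the estimate in this assay is 25000 nM, with a range from 8000 nM to 80000 nM.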

Compound 3, concentration for 50% growth inhibition: 17600 nM
Compound 3: middle estimate off by 1.4-fold (0.15 log units), on the high side; low and high end bracket the measured number.
By their numbers in this assay, from the lowest: compounds 2 and 3 (each within the scatter of the next); then compound 1.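

In this assay, a 1.3-fold higher number from compound 2 to compound 3 (0.13 log units; within the scatter) means that methoxycarbonyl and tert-butyl cannot be told apart at this place, para to a large group. Methoxycarbonyl in place of hydrogen gives a 3.0-fold lower number from compound 1 to compound 3 (0.48 log units; beyond the scatter), so a second group at this position separates from the hydrogen of compound 1, and the gain seen with tert-butyl is not unique to that group. No supporting measurement is available to explain this result. On these data alone, whether an amine, a carboxylic acid or a longer chain at this place would keep that gain remains open.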